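Adding a Hydroxy Group to an Inactive Ester

A few compounds are considered here, and "the series" means these few. Any claim that something is new, unique, unknown or untested is made for them only; others in the source may bear on it.

Measured compounds:
compound 1 `CCOC(=O)c1cnc(-c2ccccc2)s1` — > 100000 nM
compound 2 `O=C(c1sc(-c2ccccc2O)nc1O)N1CCCCO1` — 81 nM
compound 3 `CCn1nnc(-c2sc(-c3cccc(NC)c3)nc2O)n1` — 1020 nM

In an assay on HEK293 cells for inhibition of transient receptor potential cation channel subfamily M member 8 (Homo sapiens), read by FLIPR, with stated times of 5 min and 3 min (on this read-out higher numbers stand for weaker inhibition and lower numbers for stronger inhibition), compound 1 reaches only the limit of the assay, > 100000 nM, a limit rather than a number (the limit of > 100000 nM in this assay, at which 1 of the 3 values shown sits). Compound 2 gives 81 nM in this assay. Compound 3 gives 1020 nM in this assay. Both of these carry a hydroxy on the shared five-membered core, which compound 1 lacks. Compound 4 `CCOC(=O)c1sc(-c2ccccc2)nc1O` differs from compound 1 by hydroxy in place of hydrogen on an aromatic carbon. Among the measured compounds shown here, no measured pair shows this step directly, so its size is inferred. The expected step of an at least 33-fold lower number from compound 1 to compound 4 (1.52 log units; beyond the scatter) is a gain in potency beyond the scatter, because compound 2 with the same hydroxy gives 81 nM and compound 3 with the same hydroxy gives 1020 nM. Compound 4 is therefore estimated at 3000 nM, within 400 nM to 30000 nM.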

Compound 4, half-maximal inhibitory concentration: 32 nM
For compound 4 the middle estimate is 94-fold (1.97 log units) above the measured one, outside the stated range (below it).
By their numbers in this assay, from the lowest: compound 4; then compound 2; then compound 3. At a limit, above all of these: compound 1.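

Placing hydroxy instead of hydrogen on this aromatic carbon, next to the ring nitrogen, gives an at least 3100-fold lower number from compound 1 to compound 4 (3.49 log units; beyond the scatter) in this assay, with the ethoxycarbonyl group left in place. The earlier compounds shown here carried the hydroxy only together with other differences, so they did not isolate this single change. Going by these compounds, the true size of the step stays unknown, since it starts from a limit: the limit of > 100000 nM in this assay, at which 1 of the 4 values shown sits.

On these data alone, whether a methoxy group or an amine could replace the hydroxy here remains open. So does whether the step would persist with a carboxylic acid in place of the ethoxycarbonyl group.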